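Aryl swap on the shared core: compound 3 to compound 4

The compounds below may be only part of what the source reports. "The series", "measured", "known", "first", "only" and "open" are said of these compounds alone.

Values in a functional assay on FM3A cells (Mus musculus) for antiproliferative activity; on this read-out higher numbers stand for weaker inhibition and lower numbers for stronger inhibition:
- compound 1 `COc1cc(C(=O)c2sc(-c3cccc([N+](=O)[O-])c3)cc2N)cc(OC)c1OC`: 17 nM
- compound 2 `COc1cc(C(=O)c2sc(-c3ccncc3)cc2N)cc(OC)c1OC`: 150 nM
- compound 3 `COc1cc(C(=O)c2sc(-c3ccccc3Cl)cc2N)cc(OC)c1OC`: 34 nM
- compound 4 `COc1cc(C(=O)c2sc(-c3ccsc3)cc2N)cc(OC)c1OC`: not yet measured

Compound 3 lies within the scatter of compound 1 and clearly under compound 2. The change to compound 4 is thiophen-3-yl in place of 2-chlorophenyl on an aromatic carbon. Within the data shown here, no measured compound carries thiophen-3-yl, so the evidence is indirect. Three measured swaps at this place bear on it. Of these, a 2.0-fold higher number from compound 1 to compound 3 (0.30 log units; within the scatter) stayed within the scatter, while a 4.4-fold lower number from compound 2 to compound 3 (0.64 log units; beyond the scatter) and an 8.8-fold higher number from compound 1 to compound 2 (0.95 log units; beyond the scatter) were modest. As far as these compounds go, no step beyond the scatter is therefore expected in this assay, and the direction stays open. The estimate amounts to a 1.2-fold higher number from compound 3 to compound 4 (0.07 log units; within the scatter). Compound 4 is expected at 40 nM, within an estimated range of 15 nM to 110 nM.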

Compound 4, half-maximal inhibitory concentration: 3.7 nM
For compound 4 the middle estimate is 11-fold (1.03 log units) above the measured one; the measured number lies below the stated range.
By their numbers in this assay, from the lowest: compound 4; then compounds 1 and 3 (each within the scatter of the next); then compound 2.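

Thiophen-3-yl on this aromatic carbon next to the ring sulfur gives a 9.2-fold lower number from compound 3 to compound 4 (0.96 log units; beyond the scatter) and a 4.6-fold lower number from compound 1 to compound 4 (0.66 log units; beyond the scatter) and a 41-fold lower number from compound 2 to compound 4 (1.61 log units; beyond the scatter) in this assay with every step beyond the scatter. This position therefore separates these aryl groups more widely than compounds 1, 2 and 3 showed, and a five-membered aromatic ring gives the strongest inhibition of the four compounds. No data shown here account for the gain.

Whether the gain is specific to thiophen-3-yl remains open, since thiophen-2-yl and furan-3-yl do not appear among these compounds. As far as these compounds go, the effect of an added methyl or amine on the thiophene ring also remains open.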